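Swapping one lactam ring for another on the fused core

The compounds below may be only part of what the source reports. "The series", "measured", "known", "first", "only" and "open" are said of these compounds alone.

Measured so far:
compound 1 `CC(C)c1noc(N2CCC(Oc3cc(N4CCc5cc(N6CCCC6=O)ccc54)ncn3)CC2)n1`: 33 nM
compound 2 `CC(C)c1noc(N2CCC(Oc3cc(N4CCc5cc(N6CCOCC6=O)ccc54)ncn3)CC2)n1`: 15 nM

For the measured compounds named here, in an assay on CHO cells for agonist activity at Glucose-dependent insulinotropic receptor (Homo sapiens), read by a luciferase reporter and cAMP accumulation, with a stated time of 2 h (a higher number here means that more compound is needed for the effect, a lower number that less compound is needed), compound 2 gives the lowest of the two numbers measured so far, with compound 1 as its only neighbour. Going by the values given here, the single measured step is a 2.2-fold lower number from compound 1 to compound 2 (0.34 log units; beyond the scatter), a modest change that came from exchanging one small lactam ring for another on the same aromatic carbon.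

Compound 3 `CC(C)c1noc(N2CCC(Oc3cc(N4CCc5cc(N6CCC(O)CC6=O)ccc54)ncn3)CC2)n1` is not yet measured. It differs from compound 2 by 4-hydroxy-2-oxopiperidin-1-yl in place of 3-oxomorpholin-4-yl on an aromatic carbon. Among the compounds with values here, this is again an exchange of one lactam ring for another at that same position, so the measured step is the only guide, and it was modest. A step of similar size in either direction, or none beyond the scatter, seems the most likely outcome.

Compound 3 is therefore estimated at 20 nM in this assay, within a range of 7 nM to 60 nM. This estimate means an expected step of a 1.3-fold higher number from compound 2 to compound 3 (0.12 log units; within the scatter).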

Compound 3, half-maximal effective concentration: 89 nM
Compound 3: the middle estimate sits 4.5-fold (0.65 log units) below what was measured, and the stated range ends below it.
By their numbers in this assay, from the lowest: compound 2; then compound 1; then compound 3.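

In this assay, the lactams at this position are not interchangeable: 4-hydroxy-2-oxopiperidin-1-yl in place of 3-oxomorpholin-4-yl gives a 5.9-fold higher number from compound 2 to compound 3 (0.77 log units; beyond the scatter). The same group also compares poorly with 2-oxopyrrolidin-1-yl, with a 2.7-fold higher number from compound 1 to compound 3 (0.43 log units; beyond the scatter), so compound 3 needs the most compound for the effect among these three. The swap from compound 2 removes the second hetero atom of the ring and adds a hydrogen-bond donor at once, and no measurement at hand separates these changes or explains the result.

Still open, on these data alone, is how a 2-oxopiperidin-1-yl group without the hydroxy would compare, which would help to separate the effect of the hydroxy from that of the ring change. Also open, as far as these compounds go, is how this position would respond to a group other than a lactam, such as an amine or a carboxylic acid.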